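From Compound 1 to Compound 4 in a Small Series

The source may report more compounds than this note shows. Statements on the series, on what has been measured and on what is new or still open speak of the compounds shown alone.

Going by the values given here, compound 1 `N#CN/C(=N\C1CC1)Nc1cccnc1` was examined in a functional assay on the whole organism (blood, strain Wistar-Okamoto) with Rattus norvegicus as the target, with a stated time of 5 days (a lower number here means that less compound is needed, a higher number that more compound is needed for the effect), where compound 1 gives 20 mg/kg, the highest of the three numbers measured so far. Compound 2 `CC(/N=C(/NC#N)Nc1cccnc1)C(C)(C)C` gives 1 mg/kg in this assay, and compound 3 `CC(C)C(/N=C(\NC#N)Nc1cccnc1)C(C)C` gives 5 mg/kg; both gaps to compound 1 lie beyond the scatter. Compound 4 `N#CN/C(=N\CC1CCCO1)Nc1cccnc1` has not yet been tested. It differs from compound 1 in one place: (oxolan-2-yl)methyl in place of cyclopropyl on a double-bonded nitrogen. Among the compounds with values here, no measured pair shows this exact change, so the expectation rests on compounds 2 and 3, whose values show that other groups on the double-bonded nitrogen gave lower numbers than compound 1. Compound 4 is thus expected to improve, with the step estimated at a 2.0-fold lower number from compound 1 to compound 4 (0.30 log units; within the scatter). The estimate for compound 4 is 10 mg/kg, ranging from 3 mg/kg to 40 mg/kg.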

Compound 4, minimum effective dose: 50 mg/kg
Compound 4: middle estimate off by 5.0-fold (0.70 log units), on the low side; the measured number lies above the stated range.
By their numbers in this assay, from the lowest: compound 2; then compound 3; then compound 1; then compound 4.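

In this assay the exchange of cyclopropyl for (oxolan-2-yl)methyl on a double-bonded nitrogen gives a 2.5-fold higher number from compound 1 to compound 4 (0.40 log units; beyond the scatter) and so shows that a new group at this position can also raise the number, whereas the groups in compound 2 and compound 3 gave lower numbers than compound 1. Of the four compounds, only compound 4 carries an oxygen in this group. No measurement shown accounts for this rise. The compounds shown leave open whether the ring oxygen or the larger group matters, and how cyclopentylmethyl or a 2-methoxyethyl chain would read here.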